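Swapping the aryl amide of compound 2: fluorine to chlorine

A few compounds are considered here, and "the series" means these few. Any claim that something is new, unique, unknown or untested is made for them only; others in the source may bear on it.

Measured so far:
compound 1, `Cc1ccc(S(=O)(=O)NCc2ccc(CNC(=O)c3ccc(F)cc3)cc2)cc1` — 1 nM
compound 2, `O=C(NCc1ccc(CNS(=O)(=O)c2ccccc2)cc1)c1ccc(F)cc1` — 100 nM
compound 3, `COc1cccc(C(=O)NCc2ccc(CNS(=O)(=O)c3ccc(C)cc3)cc2)c1` — 10 nM

All three were tested in an assay on MDA-MB-231 cells for binding affinity to C-X-C chemokine receptor type 4 (Homo sapiens), read by immunofluorescence and microscopy, with stated times of 10 min and 30 min; on this read-out higher numbers stand for an effect only at larger amounts of compound and lower numbers for an effect already at smaller amounts. Compound 2 stands at the highest number of the three: compound 3 sits at a lower number (10 nM), and compound 1 sits lowest of all (1 nM). The step of a 100-fold higher number from compound 1 to compound 2 (2.00 log units; beyond the scatter) came from a single change, hydrogen in place of methyl on an aromatic carbon, and it was large.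

The new compound 4, `O=C(NCc1ccc(CNS(=O)(=O)c2ccccc2)cc1)c1cccc(Cl)c1`, keeps that hydrogen and instead changes the aryl amide end: 3-chlorophenyl in place of 4-fluorophenyl on a carbonyl carbon. Among the compounds with values here, only one measured step bears on this part of the molecule, a 10-fold higher number from compound 1 to compound 3 (1.00 log units; beyond the scatter), where 3-methoxyphenyl took the place of 4-fluorophenyl on the carbonyl carbon and the number rose modestly. Compound 4 carries a different group again, 3-chlorophenyl, so that step is a guide, not a template.

On that basis a modest rise in number is expected for compound 4, estimated as a 3.0-fold higher number from compound 2 to compound 4 (0.48 log units; beyond the scatter), with no change beyond the scatter also possible. Compound 4 is therefore expected to give about 300 nM, within a range from 80 nM to 1200 nM.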

Compound 4, effective concentration (reported as EC, without a stated level of effect): 1000 nM
Compound 4: middle estimate off by 3.3-fold (0.52 log units), on the low side; low and high end bracket the measured number.
By their numbers in this assay, from the lowest: compound 1; then compound 3; then compound 2; then compound 4.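

In this assay, the 3-chlorophenyl swap on the carbonyl carbon gives a 10-fold higher number from compound 2 to compound 4 (1.00 log units; beyond the scatter), which shows that this end of the molecule still matters when the methyl is absent and the number is already high. Set beside a 10-fold higher number from compound 1 to compound 3 (1.00 log units; beyond the scatter), it means that 4-fluorophenyl has now given the lower number in both pairs, against 3-methoxyphenyl with the methyl present and against 3-chlorophenyl with hydrogen in its place, although these two pairs alone cannot show how far that holds for other groups. Nothing available here explains the rise in number at this position.

The step from compound 2 to compound 4 changes both the halogen and where it sits on the ring, so it cannot say which of the two matters; a 4-chlorophenyl or a 3-fluorophenyl on the same carbonyl carbon would pull those two changes apart. Going by these compounds, it also remains open how this position responds to a quite different kind of group, such as a 4-aminophenyl or a 4-carboxyphenyl, and whether the methyl on the other aromatic ring would have the same effect alongside 3-chlorophenyl.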